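The source may hold more compounds than are shown below. What is called first, only, known or untested is meant among the compounds shown, and "the series" means these compounds.

compound 1 `O=C(N/N=C/c1cccc(Br)c1)Nc1cc2c(Nc3ccc(F)c(Cl)c3)ncnc2cc1O[C@H]1CCOC1`: 10700 nM
compound 2 `O=C(N/N=C/c1cccc(Cl)c1Cl)Nc1cc2c(Nc3ccc(F)c(Cl)c3)ncnc2cc1O[C@H]1CCOC1`: 25000 nM
compound 3 `COc1ccc(/C=N/NC(=O)Nc2cc3c(Nc4ccc(F)c(Cl)c4)ncnc3cc2O[C@H]2CCOC2)c(OC)c1OC`: 25200 nM

In a functional assay on A549 cells (Homo sapiens) for cytotoxicity, read by MTT assay, with a stated time of 72 h (on this read-out higher numbers stand for weaker inhibition and lower numbers for stronger inhibition), compound 1 gives 10700 nM, the lowest of these three numbers, and both steps away from it lie beyond the scatter. Compound 4 `COc1cc2ncnc(Nc3ccc(F)c(Cl)c3)c2cc1NC(=O)N/N=C/c1cccc(Br)c1` differs from compound 1 in one group: methyl in place of oxolan-3-yl on an oxygen on an aromatic ring. Within the data shown here, no measured step touches this place, so the evidence is only indirect. All three steps swap the phenyl group on a carbon with a double bond to nitrogen. They are modest for a 2.3-fold higher number from compound 1 to compound 2 (0.37 log units; beyond the scatter) and a 2.4-fold higher number from compound 1 to compound 3 (0.37 log units; beyond the scatter), and within the scatter for a 1.0-fold higher number from compound 2 to compound 3 (0.00 log units; within the scatter). They give no direction for the new change, so no clear shift is expected in this assay, though a modest one either way remains possible. The expected result is a 1.0-fold higher number from compound 1 to compound 4 (0.01 log units; within the scatter), an estimate close to no change. For compound 4 the estimated value is 11000 nM, with an expected range of 4500 nM to 27000 nM.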

Compound 4, half-maximal inhibitory concentration: 28100 nM
Compound 4: the middle estimate sits 2.6-fold (0.41 log units) below what was measured, outside the stated range (above it).
By their numbers in this assay, from the lowest: compound 1; then compounds 2, 3 and 4 (each within the scatter of the next).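

In this assay, the group on the oxygen on an aromatic ring turns out to matter: methyl in place of oxolan-3-yl gives a 2.6-fold higher number from compound 1 to compound 4 (0.42 log units; beyond the scatter) and so moves the result toward weaker inhibition. Among these compounds, the earlier compounds varied only the phenyl group on the carbon with a double bond to nitrogen, so this is the first sign that a second part of compound 1 also affects its number, and by a modest amount. Nothing available here explains the shift.

On these data alone, it remains open whether a chain ending in an amine, or a longer chain such as a butyl group, at this oxygen would match oxolan-3-yl or methyl. Also unresolved is whether this swap would have the same effect alongside the 2,3-dichlorophenyl or 2,3,4-trimethoxyphenyl group.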